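Extending the side chain of compound 2

A few compounds are considered here, and "the series" means these few. Any claim that something is new, unique, unknown or untested is made for them only; others in the source may bear on it.

Among the measured compounds shown here, in an ADME assay on cells (Macrophage, Mus musculus) for cytotoxicity, read by LDH release, with a stated time of 48 h (a higher number here means a weaker inhibitor, a lower number a stronger inhibitor), compound 1 (`CO[C@H]1C[C@H](O[C@H]2[C@H](C)O[C@@H](O[C@H](C(C)O)[C@@H](C)CO)C[C@@H]2OC)O[C@@H](C)[C@@H]1O`) gives 86200 nM as the only true number so far. Compound 2 (`CC[C@H](C)[C@H]1O[C@]2(CC[C@@H]1C)C[C@@H](O)C[C@@H](CCO)O2`) reads > 90000 nM in this assay and this is a limit of the assay, not a number. Compound 3 (`CCOC(=O)C1=C[C@H](C)[C@@H](O)[C@H]2OC/C(=C\CO)[C@@]12O`) reads > 90000 nM and this too is a limit. Compound 2 therefore has no number of its own, and the set is marked by the limit of > 90000 nM in this assay, at which 2 of the 3 values shown sit, as its main feature.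

Compound 4 (`CC[C@H](C)[C@H]1O[C@]2(CC[C@@H]1C)C[C@@H](O)C[C@@H](C/C=C(\C)[C@@H](O)[C@@H](C)CO)O2`) carries 3-hydroxy-4-(hydroxymethyl)-2-methylpent-1-en-1-yl in place of the hydroxymethyl of compound 2, on a saturated chain carbon bound to a saturated ring carbon (3-hydroxy-4-(hydroxymethyl)-2-methylpent-1-en-1-yl in place of hydroxymethyl on a saturated chain carbon bound to a saturated ring carbon). For the measured compounds named here, no measured step covers this change. The expected step is an at least 1.1-fold lower number from compound 2 to compound 4 (0.05 log units; that floor lies within the scatter) and it is expected to stay within the scatter, with no clear direction. Going by the values given here, this expectation rests on compound 1 at 86200 nM as the only number in the set. For compound 4 the estimate is 80000 nM with an expected range of 30000 nM to 150000 nM in this assay as well, and a bare limit is quite likely.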

Compound 4, half-maximal inhibitory concentration: > 90000 nM
Compound 4 was reported as a limit (the forecaster's own chance of this, stated with the estimate: 65%); middle value at least 1.1-fold (0.05 log units) from the limit.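

Compound 2 and compound 4 are both limits of the assay, not numbers, so no step can be read between them: the limit of > 90000 nM in this assay, at which 3 of the 4 values shown sit.

Still open, as far as these compounds go, is whether 3-hydroxy-4-(hydroxymethyl)-2-methylpent-1-en-1-yl in place of hydroxymethyl changes the read-out at all, and what true number either compound would give.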